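The source may report more compounds than this note shows. Statements on the series, on what has been measured and on what is new or still open speak of the compounds shown alone.

Measured so far in a functional assay on KETR3 cells (Homo sapiens) for inhibition, read by MTT assay, with a stated time of 120 h; a higher number here means a weaker inhibitor, a lower number a stronger inhibitor:

- Compound 1 `C/C(=C\c1ccc(NC(=O)Nc2ccc(Cl)c(C(F)(F)F)c2)cc1)C(=O)NC(C)c1ccccc1` gives > 50000 nM (a limit)
- Compound 2 `CC1CN(C(=O)c2ccc(-c3ccc(NC(=O)Nc4ccc(Cl)c(C(F)(F)F)c4)cc3)cc2)CC(C)O1` gives 41900 nM (a number)
- Compound 3 `CNC(=O)/C(C)=C/c1ccc(NC(=O)Nc2ccc(Cl)c(C(F)(F)F)c2)cc1` gives > 50000 nM (a limit)

In this assay compound 3 stands at > 50000 nM as a limit and not as a number. For the measured compounds named here, the series so far is marked by the limit of > 50000 nM in this assay, at which 2 of the 3 values shown sit, and only compound 2 gives a number.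

The next entry is compound 4 `CNC(=O)/C=C(\C)c1ccc(NC(=O)Nc2ccc(Cl)c(C(F)(F)F)c2)cc1` and the two have the same atoms, joined differently. The change is 1-methyl-2-(methylcarbamoyl)ethenyl in place of 2-(methylcarbamoyl)prop-1-en-1-yl on an aromatic carbon and it leaves the rest of the structure as it is.

Going by the values given here, the only measured step is a step that the two limits leave unreadable from compound 1 to compound 3 and it offers no size to carry over. Among the compounds with values here, it also concerns a different place, an amide-type nitrogen, so no measured step speaks directly to this change. With no readable size to draw on, no shift beyond the scatter is expected in this assay and no direction can be given.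

The expected outcome is a number no higher from compound 3 to compound 4 (the limit leaves the size open) and this rests on a limit alone. Compound 4 is estimated at 50000 nM with an expected range from 20000 nM to 100000 nM in this assay.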

Compound 4, half-maximal inhibitory concentration: > 50000 nM
Compound 4 ended at the assay's limit; the forecaster's own chance of this, stated with the estimate: 70%; the middle value lies on the limit itself.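

In this assay compound 4 gives > 50000 nM, a limit. Compound 3 also stands at a limit, so the step between compound 3 and compound 4 cannot be read. The compounds shown leave open whether 1-methyl-2-(methylcarbamoyl)ethenyl in place of 2-(methylcarbamoyl)prop-1-en-1-yl changes inhibition at all, with the series still marked by one feature: the limit of > 50000 nM in this assay, at which 3 of the 4 values shown sit.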